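A few compounds are considered here, and "the series" means these few. Any claim that something is new, unique, unknown or untested is made for them only; others in the source may bear on it.

Measured compounds, each value a limit of the assay and not a number:

- compound 1 `Cc1ccc(-c2c(CNC(C)(C)C)c(C(=O)O)nn2-c2ccccc2)cc1`: > 688000 nM
- compound 2 `CC(C)(C)NCc1c(C(=O)O)nn(-c2ccc(Cl)cc2)c1-c1ccc(Cl)cc1`: > 599000 nM
- compound 3 `CC(C)(C)NCc1c(C(=O)O)nn(-c2ccc(Cl)cc2)c1-c1ccccc1`: > 652000 nM

All three were tested in a functional assay on NCI-H460 cells (Homo sapiens) for inhibition, read by sulforhodamine B assay, with a stated time of 48 h (on this read-out lower numbers stand for stronger inhibition of growth and higher numbers for weaker inhibition of growth), and none of them returned a number. Compound 3 stands at a limit, > 652000 nM. The two other values shown are limits as well, so compound 3 cannot be ranked against them.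

Compound 4 `Cc1ccc(-c2c(CNC(C)(C)C)c(C(=O)O)nn2-c2ccc(Cl)cc2)cc1` has methyl in place of hydrogen on an aromatic carbon, para to a large group, which turns phenyl to 4-methylphenyl (methyl in place of hydrogen on an aromatic carbon). Within the data shown here, one measured step bears on this change indirectly: a step that the two limits leave unreadable from compound 2 to compound 3. It gives no size to carry over. Compound 1 also carries the 4-methylphenyl group, and its > 688000 nM is again a limit. No step beyond the scatter is therefore expected in this assay, in either direction, and compound 4 is expected to report only a limit. The expected change is an at least 1.0-fold lower number from compound 3 to compound 4 (0.01 log units; that floor lies within the scatter). For compound 4 the estimated value is 630000 nM, with an expected range of 300000 nM to 800000 nM.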

Compound 4, concentration for 50% growth inhibition: > 629000 nM
Compound 4 gave a limit, no number; the forecaster's own chance of this, stated with the estimate: 90%; the middle value is on the limit's open side.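

In this assay compound 4 gives > 629000 nM, which is a limit and not a number. Its steps from compound 1, compound 2 and compound 3 cannot be read. The compounds shown leave open whether hydrogen, methyl or chloro on the aromatic carbon makes any difference to growth inhibition in this assay.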